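Anilino series on the shared core: from compound 2 to compound 4

The source may hold more compounds than are shown below. What is called first, only, known or untested is meant among the compounds shown, and "the series" means these compounds.

Measured so far:
compound 1 `COc1cccc(NC2=CC(=O)c3nc4n(c3C2=O)[C@H]2OC[C@@H](O)[C@H]2OC4)c1` — > 4000 nM
compound 2 `O=C1C=C(Nc2cccc(Cl)c2)C(=O)c2c1nc1n2[C@H]2OC[C@@H](O)[C@H]2OC1` — 4720 nM
compound 3 `O=C1C(N2CCCC2)=CC(=O)c2c1nc1n2[C@H]2OC[C@@H](O)[C@H]2OC1` — > 16000 nM

For the measured compounds named here, in a functional assay on MCF7 cells (Homo sapiens) for inhibition, read by sulforhodamine B assay (on this read-out lower numbers stand for stronger inhibition and higher numbers for weaker inhibition), compound 2 gives 4720 nM, the only number among the three. Compound 1 gives > 4000 nM, which is a limit of the assay and not a number. Compound 3 likewise gives > 16000 nM, a limit. The step that the limit leaves unreadable from compound 1 to compound 2 cannot be sized because the limit of > 4000 nM in this assay, at which 1 of the 3 values shown sits, sits at that limit, so no readable step bears on a change of the aryl group. Compound 4 `O=C1C=C(Nc2ccc(Br)cc2)C(=O)c2c1nc1n2[C@H]2OC[C@@H](O)[C@H]2OC1` differs from compound 2 by 4-bromophenyl in place of 3-chlorophenyl on an amine nitrogen. With nothing measured to guide the size, the expected step of a 1.1-fold higher number from compound 2 to compound 4 (0.03 log units; within the scatter) is none beyond the scatter. Compound 4 is therefore estimated at 5000 nM, within 1800 nM to 14000 nM.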

Compound 4, half-maximal inhibitory concentration: 2580 nM
For compound 4 the middle estimate is 1.9-fold (0.29 log units) above the measured one; measured number inside the range.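

In this assay, for the compounds shown here, the aryl group on the amine nitrogen now has a first step between two numbers (a step of a 1.8-fold lower number from compound 2 to compound 4 (0.26 log units; within the scatter)), and 4-bromophenyl and 3-chlorophenyl stay within the scatter of each other. The comparison with 3-methoxyphenyl gives only a floor (a step of an at least 1.5-fold lower number from compound 1 to compound 4 (0.19 log units; that floor lies within the scatter)). Compound 1 stands at a limit and not a number: the limit of > 4000 nM in this assay, at which 1 of the 4 values shown sits.

This swap changes the halogen and its place on the ring together, so the two remain unseparated. As far as these compounds go, how a carboxylic acid or an amine on the phenyl ring would read also stays open.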